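The source may hold more compounds than are shown below. What is called first, only, known or untested is meant among the compounds shown, and "the series" means these compounds.

Compound 1 `c1csc(-c2ccccc2NCC2=NCCN2)c1` stands second highest of the three numbers recorded in a functional assay for activation of Alpha-1A adrenergic receptor (Homo sapiens), read by calcium flux (on this read-out lower numbers stand for an effect already at smaller amounts and higher numbers for an effect only at larger amounts of compound), where compound 1 gives 2.24 nM. Its nearest neighbour is compound 2 `Cc1ccsc1-c1ccccc1NCC1=NCCN1`, which gives 0.851 nM; the furthest is compound 3 `Cc1noc(-c2ccccc2NCC2=NCCN2)n1`, which gives 661 nM. The change to compound 4 `Cc1ccc(-c2ccccc2NCC2=NCCN2)o1` is 5-methylfuran-2-yl in place of thiophen-2-yl on an aromatic carbon, placing a five-membered aromatic ring with one hetero atom where another such ring stood. Among the measured compounds shown here, two measured steps bear on it. Adding a methyl on the five-membered ring gave a 2.6-fold lower number from compound 1 to compound 2 (0.42 log units; beyond the scatter), a modest change. Exchanging the whole ring for one with three hetero atoms gave a 300-fold higher number from compound 1 to compound 3 (2.47 log units; beyond the scatter), a large loss, and from the methylated analogue a 780-fold higher number from compound 2 to compound 3 (2.89 log units; beyond the scatter). Since compound 4 keeps a ring with a single hetero atom and gains a methyl, the step expected in this assay resembles the first far more than the second, so at most a modest move in either direction is expected, a 1.1-fold lower number from compound 1 to compound 4 (0.05 log units; within the scatter). Compound 4 is therefore estimated at 2 nM, within 0.5 nM to 8 nM.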

Compound 4, half-maximal effective concentration: 2.69 nM
Compound 4: middle estimate off by 1.3-fold (0.13 log units), on the low side, within the range that was stated.
By their numbers in this assay, from the lowest: compound 2; then compounds 1 and 4 (each within the scatter of the next); then compound 3.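

In this assay the position on the aromatic carbon accepts a furan ring carrying a methyl in place of the thiophene ring, with a 1.2-fold higher number from compound 1 to compound 4 (0.08 log units; within the scatter). The large loss seen with compound 3 therefore does not extend to every five-membered ring containing oxygen, as shown by a 250-fold lower number from compound 3 to compound 4 (2.39 log units; beyond the scatter). A methyl on the five-membered ring also does not guarantee the number of compound 2, since the furan with its methyl gives a 3.2-fold higher number from compound 2 to compound 4 (0.50 log units; beyond the scatter). Nothing available explains any of these steps. With the ring atom and the methyl changing together, the separate contribution of each remains open, and the shown compounds do not tell how plain furan-2-yl, or a five-membered ring bearing a dimethylamino group or a carboxylic acid, would read.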